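The compounds below may be only part of what the source reports. "The series", "measured", "known", "first", "only" and "open" are said of these compounds alone.

Going by the values given here, in an ADME assay on MT4 cells (Homo sapiens) for activation, read by MTT assay (on this read-out lower numbers stand for higher toxicity in this test and higher numbers for lower toxicity in this test), the two compounds read so far on the shared core give no number. Compound 1 `CCCSc1nc(C(C)c2c(F)cccc2Cl)c(C)c(=O)[nH]1` gives > 1500 nM, which is a limit of the assay. Compound 2 `CCCSc1nc(C(C)c2c(F)cccc2F)c(C)c(=O)[nH]1` gives > 3000 nM, which is also a limit, so its standing is known only as that limit. Compound 3 `CCCSc1nc(C(C)c2c(F)cccc2F)c(CC)c(=O)[nH]1` differs from compound 2 at one place, methyl in place of hydrogen on a saturated chain carbon bound to an aromatic carbon, or methyl to ethyl. Among the compounds with values here, the one measured step, a step that the two limits leave unreadable from compound 1 to compound 2, is fluoro in place of chloro on an aromatic carbon. That step lies at another place and offers no size to carry over, so the data suggest no direction and no step beyond the scatter is expected in this assay. The expected change is a step that the limit leaves unreadable from compound 2 to compound 3. Compound 3 is estimated at 4000 nM, with an expected range from 1500 nM to 20000 nM, and the assay may well report it only as a limit.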

Compound 3, half-maximal cytotoxic concentration: > 3000 nM
Compound 3 ended at the assay's limit (the forecaster's own chance of this, stated with the estimate: 80%); the middle value is on the limit's open side.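

No step can be read from compound 2 to compound 3 or from compound 1 to compound 2: in this assay, all three compounds are reported only as limits. The compounds shown leave open where the actual toxicity of each lies, and whether methyl to ethyl changes the read-out at all.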